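This account rests on a few compounds, and the source may have more. Where it says the series, first, only, none or still open, it means among the compounds named here.

Measured so far:
compound 1, `COc1ccc(-c2ccc(O[C@H]3C[C@@H](N=C=S)C3)cc2)cc1F`, gives 35.9 nM;
compound 2, `COc1ccc(-c2ccc(CO[C@H]3C[C@@H](N=C=S)C3(C)C)nc2)cc1F`, gives 246 nM;
compound 3, `S=C=N[C@H]1C[C@H](OCc2ccc(-c3ccccc3)cc2)C1`, gives 4300 nM.

In an assay on isolated protein for inhibition of N-acylethanolamine-hydrolyzing acid amidase (Homo sapiens), read by fluorescence, with a stated time of 90 min (on this read-out lower numbers stand for stronger inhibition and higher numbers for weaker inhibition), compound 3 stands at the highest number of the three, beyond the scatter from both compound 2 and compound 1. Compound 4, `S=C=N[C@H]1C[C@@H](OCc2ccc(-c3ccccc3)cc2)C1`, is not yet measured. It differs from compound 3 only in the way the ring is drawn: the two compounds have the same atoms and bonds; at least one stereo element is drawn with a configuration in one of them and without one in the other: 2 of 3 stereo elements differ; a stereocentre at a saturated ring carbon is drawn r in compound 3 and s in compound 4; a stereocentre at a saturated ring carbon is drawn r in compound 3 and s in compound 4. Among the compounds with values here, no step between two measured compounds covers this change directly, so any expectation rests on the fact that compound 3 alone carries this drawn configuration. The author expects compound 4 to come out at a lower number, with the step of a 14-fold lower number from compound 3 to compound 4 (1.16 log units; beyond the scatter) estimated to lie beyond the scatter. The expected value for compound 4 is 300 nM, within 50 nM to 1500 nM.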

Compound 4, half-maximal inhibitory concentration: 93 nM
The estimate for compound 4 lay 3.2-fold (0.51 log units) above the measured number; low and high end bracket the measured number.
By their numbers in this assay, from the lowest: compound 1; then compound 4; then compound 2; then compound 3.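

In this assay, altering only the drawn configuration at two saturated ring carbons gives a 46-fold lower number from compound 3 to compound 4 (1.66 log units; beyond the scatter), with atoms and bonds unchanged. Within the data shown here, the earlier compounds differ in more than one place, so only this pair isolates configuration at this position, and it shows that this change alone moves the number beyond the scatter. The record for this pair gives one qualification: the fact that one of compounds 3 and 4 is drawn with a defined configuration and the other without, at the place where they differ

On these data alone, it remains open whether a step of this size persists on the cores of compound 1 or compound 2. As far as these compounds go, it is also open how the same configurations behave when an amine or a carboxylic acid stands in place of the isothiocyanate.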